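The compounds below may be only part of what the source reports. "The series", "measured", "known", "first", "only" and "open" are said of these compounds alone.

Of the compounds shown here, three built on one shared core have been tested in a functional assay on A549 cells (Homo sapiens) for antiproliferative activity, with a stated time of 72 h, tested at 10 ug/mL; on this read-out lower numbers stand for a weaker effect and higher numbers for a stronger effect at the one concentration tested. Compound 1 `O=c1[nH]nc2n(c1=O)CCN2c1ccccc1`, whose six-membered aromatic ring of carbon only carries no substituent, gives 0% in this assay. Compound 2 `Cc1ccc(N2CCn3c2n[nH]c(=O)c3=O)cc1`, which carries a methyl on an aromatic carbon of that ring, gives 20%. Compound 3 `N=c1c(=O)[nH]nc2n1CCN2c1ccccc1Cl`, which carries a chloro on that ring and differs in its core as well, gives 6%. Compound 2 stands highest of the three numbers, and its distance to compound 3 as well as to compound 1 lies beyond the usual scatter. Among the measured compounds shown here, the only single-point step among the measured compounds is a number 20 percentage points higher from compound 1 to compound 2 (beyond the scatter), methyl in place of hydrogen on an aromatic carbon.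

Compound 4 `O=c1[nH]nc2n(c1=O)CCN2c1ccc(Cl)cc1` has not yet been measured in this assay. Its change from compound 2 is chloro in place of methyl on an aromatic carbon. For the measured compounds named here, no measured step swaps a methyl for a chloro, so the step from compound 1 to compound 2 bears on it only in showing that a single small group at this place moved the number by a modest amount. Compound 3 is a chloro-bearing compound with a lower number, but its core also differs, so only its value can be noted. The step is therefore expected to be small, a number 4 percentage points lower from compound 2 to compound 4 (within the scatter), within the scatter in either direction. Compound 4 is thus estimated at 16%, in a range from 0% to 35%.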

Compound 4, a percentage reported as inhibition, at one concentration (the size of the read-out at that concentration, not a potency): 0%
Compound 4: the middle estimate sits 16 percentage points above what was measured, within the range that was stated.
By their numbers in this assay, from the lowest: compounds 1, 4 and 3 (each within the scatter of the next); then compound 2.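

In this assay, the exchange of methyl for chloro on an aromatic carbon, para to a large group, gives a number 20 percentage points lower from compound 2 to compound 4 (beyond the scatter) even though each group counts a single heavy atom, so at this place the two are not interchangeable. Setting chloro in place of hydrogen on the same ring gives no change at the digits printed from compound 1 to compound 4 (within the scatter) and so leaves the read-out where the unsubstituted ring has it; among compound 1, compound 2 and compound 4, the methyl of compound 2 is the only change that lifts the number beyond the scatter. Nothing available explains why two groups of the same heavy-atom count part ways here.

The compounds shown cover only hydrogen, methyl and chloro at this place, so it remains open whether the gain belongs to methyl alone or extends to a longer chain such as ethyl, or to a methoxy, an amine or a carboxylic acid. From the compounds shown here alone, it also remains open whether methyl would give a similar step on another carbon of the ring or on a changed core such as that of compound 3.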